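From acetyl to 1-hydroxyethyl on a shared core

The source may report more compounds than this note shows. Statements on the series, on what has been measured and on what is new or still open speak of the compounds shown alone.

Measured in a physicochemical assay for solubility, read by chemiluminescence, measured as kinetic solubility; on this read-out higher numbers stand for higher solubility and lower numbers for lower solubility:
Compound 1 `CC(=O)NCc1cccc(Cn2nc(NS(=O)(=O)c3ccc(Cl)s3)c3c(Cl)cccc32)c1`: >= 226 ug/mL (a limit of the assay)
Compound 2 `CC(=O)NCc1cccc(Cn2nc(NS(=O)(=O)c3ccc(Cl)s3)c3c(C(C)=O)cccc32)c1`: 57 ug/mL

Going by the values given here, compound 2 stands at 57 ug/mL, the only actual number so far. Compound 1 has a limit of the assay, >= 226 ug/mL, and not a number. Among the compounds with values here, the single measured step, an at least 3.9-fold lower number from compound 1 to compound 2 (0.59 log units; beyond the scatter), puts acetyl in place of chloro on an aromatic carbon, and its size rests on (the limit of >= 226 ug/mL in this assay, at which 1 of the 2 values shown sits). Compound 3 `CC(=O)NCc1cccc(Cn2nc(NS(=O)(=O)c3ccc(Cl)s3)c3c(C(C)O)cccc32)c1` changes that same place, with 1-hydroxyethyl in place of acetyl on an aromatic carbon. Within the data shown here, no measured step tests this exchange directly. Among the measured compounds shown here, with an at least 3.9-fold lower number from compound 1 to compound 2 (0.59 log units; beyond the scatter) as the only guide, a modest upward move in this assay is expected, held with little confidence. The expected step is a 1.8-fold higher number from compound 2 to compound 3 (0.24 log units; within the scatter), possibly none beyond the scatter. For compound 3 the estimated value is 100 ug/mL, with an expected range from 40 ug/mL to 226 ug/mL.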

Compound 3, solubility: >= 208 ug/mL
Compound 3 ended at the assay's limit; the forecaster's own chance of this, stated with the estimate: 15%; at least 2.0-fold (0.31 log units) between middle value and limit.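

In this assay, replacing acetyl with 1-hydroxyethyl on this aromatic carbon gives an at least 3.6-fold higher number from compound 2 to compound 3 (0.56 log units; beyond the scatter), so the position responds to a change within the group as well as to replacing chloro with acetyl. Of the three groups shown at this place, only acetyl gives an actual number, while chloro and 1-hydroxyethyl both give limits of the assay. The size of the new step is therefore only a lower bound: the limit of >= 208 ug/mL in this assay, at which 1 of the 3 values shown sits.

As far as these compounds go, the step from compound 1 to compound 3 cannot be read, so the order of chloro and 1-hydroxyethyl at this place remains open. Also open, from the compounds shown here alone, is where a 1-methoxyethyl group, which keeps the chain but carries no hydroxyl hydrogen, or an amine on this aromatic carbon would fall in this assay.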